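Replacing the 4-(methylsulfanyl)phenyl group of compound 2

The compounds below may be only part of what the source reports. "The series", "measured", "known", "first", "only" and "open" are said of these compounds alone.

Among the compounds with values here, in a functional assay on DU-145 cells (Homo sapiens) for inhibition, read by trypan blue exclusion, with a stated time of 96 h (on this read-out lower numbers stand for stronger inhibition of growth and higher numbers for weaker inhibition of growth), compound 2 `CSc1ccc(/C=C(/Sc2ccc(C)cc2)C(=O)c2ccc(Br)cc2)cc1` gives 50000 nM, the higher of the two numbers so far, while compound 1 `Cc1ccc(S/C(=C/c2ccc(Cl)cc2)C(=O)c2ccc(Br)cc2)cc1` gives 10000 nM. Next comes compound 3 `COc1ccccc1/C=C(/Sc1ccc(C)cc1)C(=O)c1ccc(Br)cc1`, with 2-methoxyphenyl in place of 4-(methylsulfanyl)phenyl on a double-bonded chain carbon bound to a double-bonded chain carbon. Within the data shown here, one measured step bears on this change: a 5.0-fold higher number from compound 1 to compound 2 (0.70 log units; beyond the scatter), which altered the same ring. Among the measured compounds shown here, no measurement yet covers a 2-methoxyphenyl group, so the guidance is thin. With compound 2 at the top of the range, a modest move towards a lower number is expected in this assay. The expected step is a 2.5-fold lower number from compound 2 to compound 3 (0.40 log units; beyond the scatter). The estimate for compound 3 is 20000 nM, with a range of 6000 nM to 60000 nM.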

Compound 3, concentration for 50% growth inhibition: 9000 nM
Beside the measured number, compound 3's estimate is 2.2-fold (0.35 log units) above it, within the range that was stated.
By their numbers in this assay, from the lowest: compounds 3 and 1 (each within the scatter of the next); then compound 2.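

In this assay the 2-methoxyphenyl group undoes the loss seen with 4-(methylsulfanyl)phenyl on a double-bonded chain carbon bound to a double-bonded chain carbon, with a 5.6-fold lower number from compound 2 to compound 3 (0.74 log units; beyond the scatter) as the step. Against 4-chlorophenyl there is no separation, with a 1.1-fold lower number from compound 1 to compound 3 (0.05 log units; within the scatter) as the step, so two differently substituted rings sit level here and 4-(methylsulfanyl)phenyl alone stands apart. The change swaps sulfur for oxygen and shifts the ring position together, so the step cannot assign the gain to either. Open, as far as these compounds go, is how an unsubstituted phenyl or a ring carrying an amine or carboxylic acid would behave. Nothing at hand explains these steps.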